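The source may report more compounds than this note shows. Statements on the series, on what has been measured and on what is new or still open speak of the compounds shown alone.

Compound 1 `C=CCn1nc(-c2cccnc2)c2ccccc2c1=O` is the more potent of the two measured compounds in a functional assay (trachea) with Cavia porcellus as the target (on this read-out lower numbers stand for stronger inhibition and higher numbers for weaker inhibition), where compound 1 gives 2140 nM. Among the compounds with values here, its only measured neighbour is compound 2 `CCOC(=O)CCCn1nc(-c2cccnc2)c2ccccc2c1=O`, which in this assay gives 10000 nM; the step of a 4.7-fold higher number from compound 1 to compound 2 (0.67 log units; beyond the scatter) is the single comparison available and shows that replacing the vinyl of compound 1 with a longer, ester-bearing chain costs potency.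

Compound 3 `O=c1c2ccccc2c(-c2cccnc2)nn1CCO` has not yet been measured in this assay. It differs from compound 1 as follows: hydroxymethyl in place of vinyl on a saturated chain carbon bound to an aromatic nitrogen. Within the data shown here, the change is made at the same place as the step from compound 1 to compound 2, and that step is the only one that bears on it, though the group entering in compound 3 is shorter than the one entering in compound 2 and carries a hydrogen-bond donor and acceptor.

Taking the weakening seen in the step from compound 1 to compound 2 as the guide, compound 3 is expected to sit somewhat weaker than compound 1, with an estimated step of a 2.1-fold higher number from compound 1 to compound 3 (0.32 log units; beyond the scatter). The estimate for compound 3 in this assay is 4500 nM, with a range from 1500 nM to 13000 nM.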

Compound 3, half-maximal inhibitory concentration: 4570 nM
Estimate against measurement, compound 3: 1.0-fold (0.01 log units) below; the range from low to high includes it.
By their numbers in this assay, from the lowest: compound 1; then compound 3; then compound 2.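

In this assay, this place on a saturated chain carbon bound to an aromatic nitrogen now has a second substituent to compare, and the result separates two levels of loss. Exchanging allyl for 2-hydroxyethyl gives a 2.1-fold higher number from compound 1 to compound 3 (0.33 log units; beyond the scatter) and so remains a modest weakening beyond the scatter, yet the hydroxy-bearing chain also recovers part of the loss seen with the ester, with a 2.2-fold lower number from compound 2 to compound 3 (0.34 log units; beyond the scatter) in the same assay. Neither replacement improves on the allyl of compound 1, so the place accepts a hydrogen-bond donor and acceptor at a modest cost, and the numbers now run in a graded order instead of resting on a single step, although nothing measured here explains that order.

The compounds shown leave open whether the weaker number of compound 2 follows from the length of its chain or from the ester at its end, which a 2-hydroxyethyl homologue with a longer chain or a plain propyl chain would help to separate. They also leave open how an amine or a carboxylic acid at the end of the chain would read in this assay.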